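Removing the amino group from compound 2

The source may hold more compounds than are shown below. What is called first, only, known or untested is meant among the compounds shown, and "the series" means these compounds.

Compound 1 `C#Cc1cn([C@@H]2O[C@H](CO)[C@@H](O)[C@H]2O)c2ncnc(NC)c12` gives 1380 nM in a functional assay on K562 cells (Homo sapiens), read by MTT assay, with a stated time of 72 h; a lower number here means a stronger inhibitor, a higher number a weaker inhibitor. Compound 2 `C#Cc1cn([C@@H]2O[C@H](CO)[C@@H](O)[C@H]2O)c2nc(N)nc(OC)c12` reaches only the limit of this assay, > 20000 nM.

Compound 2 therefore stands at the limit of > 20000 nM in this assay, at which 1 of the 2 values shown sits, and has no number of its own in this assay. Compound 1 stands at a measured value. Compound 3 `C#Cc1cn([C@@H]2O[C@H](CO)[C@@H](O)[C@H]2O)c2ncnc(OC)c12` is not yet measured; it differs from compound 2 in one place: hydrogen in place of amino on an aromatic carbon. Among the compounds with values here, no step between measured compounds bears on this change, so its size in this assay can only be expected, not read from the data. Because compound 2 sits at the limit of > 20000 nM in this assay, at which 1 of the 2 values shown sits, the step cannot be given as a number from the measured side; for compound 3 the expected step is a move toward stronger inhibition of an at least 2.5-fold lower number from compound 2 to compound 3 (0.39 log units; beyond the scatter), with a fair chance that only a limit is reported again. Compound 3 is estimated at 8000 nM, expected between 2000 nM and 30000 nM.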

Compound 3, half-maximal inhibitory concentration: 380 nM
Beside the measured number, compound 3's estimate is 21-fold (1.32 log units) above it; measured number below the stated range.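

In this assay the loss of the amino group from the aromatic carbon between two ring nitrogen atoms gives an at least 52-fold lower number from compound 2 to compound 3 (1.72 log units; beyond the scatter) and shows that, with the methoxy group in place, this position strongly affects the read-out. Exchanging methylamino for methoxy on the shared core gives a 3.6-fold lower number from compound 1 to compound 3 (0.56 log units; beyond the scatter) and is a modest change by comparison, so compound 3 shows that a methoxy group is compatible with a low number once hydrogen occupies that carbon. The larger step is only a lower bound because compound 2 has no number of its own: the limit of > 20000 nM in this assay, at which 1 of the 3 values shown sits.

As far as these compounds go, it remains open whether an amino group would cost as much with methylamino in place of methoxy. The compounds shown also leave open how a fluorine atom or a methyl group would read on the carbon that carries hydrogen in compound 3.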